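Nitro in place of methoxy, second occurrence in the series

A few compounds are considered here, and "the series" means these few. Any claim that something is new, unique, unknown or untested is made for them only; others in the source may bear on it.

Compound 1 `COc1ccc(S(=O)(=O)Oc2ccccc2/C=C(\C#N)C(=O)Nc2nnc(Cc3ccc(F)cc3)s2)cc1` gives 76% in a functional assay on RS4-11 cells (Homo sapiens) for inhibition, read by CCK-8 assay, with a stated time of 48 h, tested at 20 uM; on this read-out lower numbers stand for less inhibition of growth and higher numbers for more inhibition of growth at the one concentration tested. Compound 2 `N#C/C(=C\c1ccccc1OS(=O)(=O)c1ccc([N+](=O)[O-])cc1)C(=O)Nc1nnc(Cc2ccc(F)cc2)s1` gives 55% in this assay; the change is nitro in place of methoxy on an aromatic carbon, and the step is a number 21 percentage points lower from compound 1 to compound 2 (beyond the scatter). Compound 3 `COc1ccc(S(=O)(=O)Oc2ccccc2/C=C(\C#N)C(=O)Nc2nnc(Cc3ccc(C)cc3)s2)cc1` gives 79% in this assay, a step of a number 3 percentage points higher from compound 1 to compound 3 (within the scatter), so compound 3 and compound 1 read alike within the usual scatter.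

Compound 4 `Cc1ccc(Cc2nnc(NC(=O)/C(C#N)=C/c3ccccc3OS(=O)(=O)c3ccc([N+](=O)[O-])cc3)s2)cc1` has not yet been measured in this assay. It differs from compound 3 by nitro in place of methoxy on an aromatic carbon, the same change that separates compound 2 from compound 1, made here on the core of compound 3, which differs from the core of compound 1 by methyl in place of fluoro on an aromatic carbon. The place of the change reads the same in both pairs.

Going by the values given here, the expected step is a number 21 percentage points lower from compound 3 to compound 4 (beyond the scatter) in this assay, because the one earlier instance of this change gave a number 21 percentage points lower from compound 1 to compound 2 (beyond the scatter) and compound 3 starts near compound 1. This rests on a single pairing, so the range is kept wide. For compound 4 the estimated value in this assay is 58%, between 44% and 72%.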

Compound 4, percent growth inhibition at one concentration: 64%
The estimate for compound 4 lay 6 percentage points below the measured number; low and high end bracket the measured number.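

In this assay, going by these compounds alone, nitro in place of methoxy on the core of compound 3 gives a number 15 percentage points lower from compound 3 to compound 4 (beyond the scatter), and the two instances of this change do not differ: the same change on two cores in this assay, a number 21 percentage points lower (beyond the scatter) from compound 1 to compound 2 and a number 15 percentage points lower (beyond the scatter) from compound 3 to compound 4, 6 percentage points apart, within the scatter of two such steps Methyl in place of fluoro, read with nitro in place, gives a number 9 percentage points higher from compound 2 to compound 4 (within the scatter), and this change also reads alike in its two instances: the same change on two cores in this assay, a number 3 percentage points higher (within the scatter) from compound 1 to compound 3 and a number 9 percentage points higher (within the scatter) from compound 2 to compound 4, 6 percentage points apart, within the scatter of two such steps This shows that the nitro change carried between these two cores, but it rests on only two pairs read at one concentration, so it does not show that the step would hold on a core that differs more, or why it occurs.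

The compounds shown leave open how an amine or a carboxylic acid would read in the place held by methoxy and nitro. They also leave open whether a longer chain, such as propyl, in the place held by fluoro and methyl would keep the reading of compound 3.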